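Heteroaryl swap on the core: compound 2 to compound 4

The compounds below may be only part of what the source reports. "The series", "measured", "known", "first", "only" and "open" are said of these compounds alone.

Read-outs below come from a functional assay on A2780 cells (Homo sapiens) for inhibition; a higher number here means a weaker inhibitor, a lower number a stronger inhibitor.
- compound 1, `CCNC(=O)c1noc(-c2cc(C(C)C)c(O)cc2O)c1-c1cc(COCC(N)=O)no1`: "not determined" (no result reported) in this assay
- compound 2, `CCNC(=O)c1noc(-c2cc(C(C)C)c(O)cc2O)c1-c1cc(CNCCO)no1`: "not determined" (no result reported) in this assay
- compound 3, `CCNC(=O)c1noc(-c2cc(C(C)C)c(O)cc2O)c1-c1cc(CN(CC)CC)no1`: 78 nM in this assay

Compound 2 stands without a single number in this assay, and compound 1 is in the same position; only compound 3 carries a value. For the measured compounds named here, no pair of measured compounds differing in one place exists, so no step size is known for the series.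

Compound 4 is `CCNC(=O)c1noc(-c2cc(C(C)C)c(O)cc2O)c1-c1cnn(C(C)C)c1`. It differs from compound 2 as follows: 1-isopropyl-1H-pyrazol-4-yl in place of 3-(((2-hydroxyethyl)amino)methyl)-1,2-oxazol-5-yl on an aromatic carbon. Since compound 2 has no number, the step to compound 4 cannot be sized from the data, and neither direction can be backed by a measured pair. Going by the values given here, the only anchor is compound 3, which gives 78 nM, and the expectation for compound 4 is set near that anchor with a wide margin because compound 3 gives 78 nM from a different substituent at the same position. Compound 4 is estimated at 150 nM, with a range of 40 nM to 600 nM.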

Compound 4, half-maximal inhibitory concentration: 21 nM
Compound 4: middle estimate off by 7.1-fold (0.85 log units), on the high side, outside the stated range (below it).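

For the compounds shown here, compound 2 carries no single number in this assay, so no step to compound 4 at 21 nM can be read. The compounds shown leave open how much of that value the 1-isopropyl-1H-pyrazol-4-yl group itself accounts for. No evidence bears on this result.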